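Shortening the Chain on a Trifluoromethyl Chalcone Core

The source may hold more compounds than are shown below. What is called first, only, known or untested is meant among the compounds shown, and "the series" means these compounds.

Compound 1, `CCCc1c(O)ccc(C(=O)/C=C/c2ccc(C(F)(F)F)cc2)c1O` — "not determined" (no result reported) in a functional assay on MCF7 cells (Homo sapiens) for inhibition, read by sulforhodamine B assay, with a stated time of 48 h; on this read-out lower numbers stand for stronger inhibition of growth and higher numbers for weaker inhibition of growth
Compound 2, `CCCc1c(O)ccc(C(=O)/C=C/c2ccc(OC)cc2)c1O` — 13300 nM
Compound 3, `CCCc1c(O)ccc(C(=O)/C=C/c2ccc(F)cc2)c1O` — "not determined" (no result reported)
Compound 4, `Cc1c(O)ccc(C(=O)/C=C/c2ccc(C(F)(F)F)cc2)c1O` — not yet measured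

Of the three measured compounds, only compound 2 carries a number: in this assay compound 2 gives 13300 nM. Compound 1 is recorded as "not determined" (no result reported) and compound 3 as "not determined" (no result reported), so compound 1 stands nowhere on the scale; the only fixed point in this series is compound 2.

Compound 4 is reached from compound 1 by one change: hydrogen in place of ethyl on a saturated chain carbon bound to an aromatic carbon. Among the measured compounds shown here, no step between two measured compounds shows how such a change moves the read-out, and compound 1 itself has no number to start from. The step is therefore expected to stay within the scatter of this assay, in no firm direction. Leaning on compound 2 as the sole anchor, compound 4 is expected to give about 12000 nM, with a range from 3000 nM to 50000 nM.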

Compound 4, concentration for 50% growth inhibition: 19300 nM
The estimate for compound 4 lay 1.6-fold (0.21 log units) below the measured number; low and high end bracket the measured number.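

Among the compounds shown here, compound 1 has no number in this assay, so no step to compound 4 can be read, and compound 4 stands alone at 19300 nM. No evidence bears on this result. The compounds shown leave open how the change from propyl to methyl moves growth inhibition.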